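Chloro to Methyl on the Sulfonamide Aryl Ring

The source may report more compounds than this note shows. Statements on the series, on what has been measured and on what is new or still open speak of the compounds shown alone.

Two pairs of sulfonamides are compared in a functional assay on MCF7 cells (Homo sapiens) for antiproliferative activity, read by MTT assay, with a stated time of 48 h; a higher number here means a weaker inhibitor, a lower number a stronger inhibitor. Compound 1 `COc1ncc(-c2ccc3nc(N)nn3c2)cc1NS(=O)(=O)c1ccc(Cl)cc1` gives 1820 nM, while compound 2 `COc1ncc(-c2ccc3nc(N)nn3c2)cc1NS(=O)(=O)c1ccc(C)cc1`, which carries methyl in place of chloro on an aromatic carbon, gives 1550 nM. The step of a 1.2-fold lower number from compound 1 to compound 2 (0.07 log units; within the scatter) leaves the two compounds within the scatter of each other. Compound 3 `COc1ncc(-c2ccn3nc(NC(C)=O)nc3c2)cc1NS(=O)(=O)c1ccc(Cl)cc1` is built on a different core; how that core differs from the core of compound 1 is not broken down here. In this assay compound 3 gives 1240 nM, a number within the scatter of both compound 1 and compound 2. Compound 4 `COc1ncc(-c2ccn3nc(NC(C)=O)nc3c2)cc1NS(=O)(=O)c1ccc(C)cc1` has not yet been measured. It differs from compound 3 by methyl in place of chloro on an aromatic carbon, the same change at the same place as that between compound 1 and compound 2. Since the earlier step of a 1.2-fold lower number from compound 1 to compound 2 (0.07 log units; within the scatter) stayed within the scatter, a similar outcome is expected for the new pair. The expected step in this assay is a 1.2-fold lower number from compound 3 to compound 4 (0.07 log units; within the scatter). Compound 4 is therefore estimated at about 1050 nM, with an expected range from 500 nM to 2200 nM.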

Compound 4, half-maximal inhibitory concentration: 1360 nM
Compound 4: middle estimate off by 1.3-fold (0.11 log units), on the low side; low and high end bracket the measured number.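

In this assay the change from 4-chlorophenyl to 4-methylphenyl gives a 1.1-fold higher number from compound 3 to compound 4 (0.04 log units; within the scatter) on the second core, and set beside the earlier pair it behaves no differently on the two cores: the same change on two cores in this assay, a 1.2-fold lower number (0.07 log units; within the scatter) from compound 1 to compound 2 and a 1.1-fold higher number (0.04 log units; within the scatter) from compound 3 to compound 4, 1.3-fold (0.11 log units) apart, within the scatter of two such steps. Within this series, then, the step carried from one core to the other in the only sense these data allow, since on both cores the paired compounds stay within the scatter of each other. Within the data shown here, this does not show that either group has any effect of its own on antiproliferative activity, and with only two cores and a step too small to read a direction from, it gives no rule for cores beyond these.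

On these data alone, whether a trifluoromethyl, an amine, a carboxylic acid or a longer chain in that place on the aromatic ring would move the number beyond the scatter stays open. Also open, as far as these compounds go, is whether such a group would then act alike on both cores.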